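This account rests on a few compounds, and the source may have more. Where it says the series, first, only, none or still open, it means among the compounds named here.

Series notes. Three compounds have a number in an ADME assay on the whole organism (serum, Rattus norvegicus) for protein binding; a higher number here means a larger unbound share of the compound, a lower number a smaller unbound share. Compound 1 `CCC(CC)C1C(C(=O)c2ccc(OC)cc2)=C(O)C(=O)N1c1ccc(-c2ccon2)cc1` gives 0.0002; compound 2 `COc1ccccc1C1C(C(=O)C(C)(C)C)=C(O)C(=O)N1c1ccc(-c2ccon2)cc1` gives 0.002; compound 3 `CC(C)(C)C(=O)C1=C(O)C(=O)N(c2ccc(-c3ccon3)cc2)C1c1ccccc1OCCO` gives 0.012, the highest of the three, with the gap to compound 2 being the step of a 6.0-fold higher number from compound 2 to compound 3 (0.78 log units; beyond the scatter) and compound 1 lying furthest below it. Compound 4 `CC(C)(C)C(=O)C1=C(O)C(=O)N(c2ccc(-c3cccs3)cc2)C1c1ccccc1OCCO` is still to be measured in this assay. It differs from compound 3 in one place: thiophen-2-yl in place of 1,2-oxazol-3-yl on an aromatic carbon. Going by the values given here, no measured step touches this part of the structure: compounds 1, 2 and 3 all carry the 1,2-oxazol-3-yl group, and the one measured step, a 6.0-fold higher number from compound 2 to compound 3 (0.78 log units; beyond the scatter), concerns the other end of the molecule and gives no direct guide here. For compound 4 a small shift is therefore expected, probably not beyond the scatter, and if anything downward, as the group that enters counts one hydrogen-bond acceptor fewer. Compound 4 is expected at 0.006, with a range from 0.0015 to 0.025. This amounts to an expected step of a 2.0-fold lower number from compound 3 to compound 4 (0.30 log units; within the scatter).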

Compound 4, unbound fraction: 0.001
Compound 4: the middle estimate sits 6.0-fold (0.78 log units) above what was measured; measured number outside the range, below it.
By their numbers in this assay, from the lowest: compound 1; then compounds 4 and 2 (each within the scatter of the next); then compound 3.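

The para-linked five-membered ring, unchanged in compounds 1, 2 and 3, proves to be a sensitive place in this assay: thiophen-2-yl in place of 1,2-oxazol-3-yl gives a 12-fold lower number from compound 3 to compound 4 (1.08 log units; beyond the scatter). The exchange keeps the same count of heavy atoms and a five-membered aromatic ring, yet swaps the ring's nitrogen and oxygen for a sulfur and leaves fewer hydrogen-bond acceptors, so a change of ring hetero atoms alone is enough to move this read-out beyond the scatter. No measurement shown here accounts for the size of this step.

A single pair cannot separate the contribution of the lost nitrogen from that of the lost oxygen or the added sulfur. Still open, going by these compounds, are how an unsubstituted phenyl or a pyridin-3-yl group would read at this carbon, and whether the same exchange carries over to the core of compound 2.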